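The source may hold more compounds than are shown below. What is called first, only, known or untested is meant among the compounds shown, and "the series" means these compounds.

Measured so far in an ADME assay on liver for metabolic stability, with Liver microsome (Homo sapiens) as the target, read by LC-MS, using microsomes; a higher number here means faster removal of the compound, a lower number slower removal:
compound 1 `CC1(C[C@@H](O)C(=O)N2C[C@H]3C[C@H]3[C@H]2C(=O)NCc2cc(Cl)ccc2-n2cnnn2)CC1`, 12 mL.min-1.g-1
compound 2 `CC(C)(C)[C@@H](O)C(=O)N1N=CC[C@H]1C(=O)NCc1cc(Cl)ccc1-n1cnnn1`, < 12 mL.min-1.g-1
compound 3 `O=C(NCc1cc(Cl)ccc1-n1cnnn1)[C@@H]1CC=NN1C(=O)[C@H](O)C1CCCCC1`, 63 mL.min-1.g-1

The value given for compound 2 is a limit of this assay, (the limit of < 12 mL.min-1.g-1 in this assay, at which 1 of the 3 values shown sits), and not a number. Among the two numbers, compound 1 stands lowest; the nearest, compound 3, lies a step away that is beyond the scatter. Within the data shown here, the single measured step, an at least 5.2-fold higher number from compound 2 to compound 3 (0.72 log units; beyond the scatter), shows that cyclohexyl in place of tert-butyl raised the number by a margin beyond the scatter.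

Compound 4 `CCCC[C@@H](O)C(=O)N1C[C@H]2C[C@H]2[C@H]1C(=O)NCc1cc(Cl)ccc1-n1cnnn1` is not yet measured. It differs from compound 1 as propyl in place of 1-methylcyclopropyl on a saturated chain carbon, two bonds along the chain from a carbonyl carbon and an oxygen on a saturated carbon. This swaps a three-membered ring for an open chain rather than adding a larger ring, so the step from compound 2 to compound 3 bears on it only loosely. For compound 4 a small rise, within the scatter, is expected, a 1.5-fold higher number from compound 1 to compound 4 (0.18 log units; within the scatter). Compound 4 is therefore estimated at 18 mL.min-1.g-1, with a range from 8 mL.min-1.g-1 to 40 mL.min-1.g-1.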

Compound 4, intrinsic clearance in microsomes: 32 mL.min-1.g-1
Estimate against measurement, compound 4: 1.8-fold (0.25 log units) below, within the range that was stated.
By their numbers in this assay, from the lowest: compound 1; then compounds 4 and 3 (each within the scatter of the next).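

In this assay, among these compounds, propyl in place of 1-methylcyclopropyl gives a 2.7-fold higher number from compound 1 to compound 4 (0.43 log units; beyond the scatter) and so gives the first reading of this position on the core of compound 1. The earlier step changed tert-butyl to cyclohexyl on a different core, so it did not show that this position also moves the number on the core of compound 1. It also shows that an open chain and a three-membered ring at this place are not interchangeable here, although nothing shown gives a cause for this step.

The compounds shown leave open whether a cyclopropyl without the methyl, or a longer chain, at this place would stand nearer compound 1 or compound 4. They also leave open whether the same change would give a similar step on the core of compound 2.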